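A chlorine-fluorine ring in place of three fluorines

The source may hold more compounds than are shown below. What is called first, only, known or untested is meant among the compounds shown, and "the series" means these compounds.

Measured compounds:
- Compound 1, `CC(C)[C@H](NC(=O)CCN(C)C)c1cccc(F)c1N1CCN(C(=O)[C@@H]2CN(C(C)C)C[C@H]2c2cc(F)c(F)c(F)c2)CC1`, in an assay on HEK293 cells for displacement of a labelled ligand from Melanocortin receptor 4 (Homo sapiens) (on this read-out lower numbers stand for stronger inhibition and higher numbers for weaker inhibition), gives 250 nM.
- Compound 2, `CCC(=O)N1C[C@@H](C(=O)N2CCN(c3ccc(C)cc3[C@@H](NC(=O)CCN(C)C)C(C)C)CC2)[C@H](c2ccc(Cl)cc2)C1`, in this assay gives 4.6 nM.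
- Compound 3, `CNCC(=O)N[C@H](c1cc(C)ccc1N1CCN(C(=O)[C@@H]2CN(C3CCOCC3)C[C@H]2c2ccc(Cl)cc2)CC1)C(C)C`, in this assay gives 2.1 nM.

Compound 1 has the highest number of the three, and both compound 2 and compound 3 sit far below it, beyond the usual scatter. Those two, however, differ from compound 1 in several places at once, so their values only show what each whole molecule does.

Compound 4, `CC(C)[C@H](NC(=O)CCN(C)C)c1cccc(F)c1N1CCN(C(=O)[C@@H]2CN(C(C)C)C[C@H]2c2ccc(F)c(Cl)c2)CC1`, changes compound 1 in a single spot: 3-chloro-4-fluorophenyl in place of 3,4,5-trifluorophenyl on a saturated ring carbon. For the measured compounds named here, no measured pair isolates this change. Compound 2 with 4.6 nM and compound 3 with 2.1 nM both carry a chlorine-bearing ring on that carbon, but they also differ elsewhere, so they give only a loose hint. A drop in the number, of moderate size and beyond the scatter, is expected for the step of a 3.1-fold lower number from compound 1 to compound 4 (0.49 log units; beyond the scatter). Compound 4 is therefore estimated at 80 nM, within a range of 20 nM to 300 nM.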

Compound 4, inhibition constant: 260 nM
Compound 4: middle estimate off by 3.3-fold (0.51 log units), on the low side; measured number inside the range.
By their numbers in this assay, from the lowest: compound 3; then compound 2; then compounds 1 and 4 (each within the scatter of the next).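

Placing 3-chloro-4-fluorophenyl instead of 3,4,5-trifluorophenyl on this saturated ring carbon gives, in this assay, a 1.0-fold higher number from compound 1 to compound 4 (0.02 log units; within the scatter) and so the read-out does not tell these two rings apart on the core of compound 1. For the compounds shown here, this is the first pair that isolates the change, and it shows that a chlorine on this ring does not by itself bring the number down on this core. The far lower values of compound 2 and compound 3, which also carry a chlorine-bearing ring, therefore cannot be credited to that ring alone.

Nothing available here bears on why the two rings read alike. Still open, going by these compounds, are whether a methoxy group or a nitrile on this ring would move the number, and which of the other differences from compound 1 accompany the lower values of compound 2 and compound 3.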